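Methylating One Hydroxy of a Salicylaldimine Inhibitor

The source may report more compounds than this note shows. Statements on the series, on what has been measured and on what is new or still open speak of the compounds shown alone.

Among the measured compounds shown here, the series is built around a benzyloxy-substituted anilide of an aromatic aldehyde, and the three measured members differ only in the substituents on the aldehyde ring. Compound 1 `Oc1ccc(O)c(/C=N/c2ccc(OCc3ccccc3)cc2)c1` carries two hydroxy groups and, in an assay on isolated protein for inhibition of Amine oxidase [flavin-containing] B (Homo sapiens), read by fluorescence and Amplex Red, with stated times of 15 min and 20 min (on this read-out higher numbers stand for weaker inhibition and lower numbers for stronger inhibition), gives 1230 nM, the lowest of the three numbers. Compound 2 `COc1ccc(/C=N/c2ccc(OCc3ccccc3)cc2)c(O)c1` carries one hydroxy and one methoxy group and gives 23600 nM in this assay. Compound 3 `Oc1ccc2ccccc2c1/C=N/c1ccc(OCc2ccccc2)cc1`, whose aldehyde ring is fused to a second ring and carries a single hydroxy, gives 19200 nM. Both of these values lie well beyond the scatter of the number for compound 1, so compound 1 is the most potent of the three measured compounds.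

Compound 4 `COc1ccc(O)c(/C=N/c2ccc(OCc3ccccc3)cc2)c1` has not yet been measured. It is derived from compound 1 by a single change: methyl in place of hydrogen on an oxygen on an aromatic ring. The other hydroxy group of compound 1 is kept. For the measured compounds named here, no single-point step between measured compounds is available, but compound 2 shows that a hydroxy-and-methoxy pattern gives a far higher number than compound 1, although at a different position. A moderate loss is therefore expected from compound 1 to compound 4, as a 3.3-fold higher number from compound 1 to compound 4 (0.51 log units; beyond the scatter). Compound 4 is estimated to give 4000 nM in this assay, within a range of 1200 nM to 15000 nM.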

Compound 4, half-maximal inhibitory concentration: 10700 nM
Compound 4: the middle estimate sits 2.7-fold (0.43 log units) below what was measured; measured number inside the range.
By their numbers in this assay, from the lowest: compound 1; then compounds 4, 3 and 2 (each within the scatter of the next, the first and the last beyond it).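

In this assay, the replacement of this hydroxy by methoxy gives the series its first step that changes one place alone: an 8.7-fold higher number from compound 1 to compound 4 (0.94 log units; beyond the scatter), a loss beyond the scatter. The earlier compounds shown here could not show this, as no two of them differed in one place, and the pattern seen in compound 2 came with its methoxy elsewhere. Here a single methyl on an oxygen on an aromatic ring, with the other hydroxy kept, is enough to weaken inhibition, so at this position the hydrogen on the oxygen cannot be exchanged for methyl without a cost. Nothing available here accounts for the size of this loss.

Still open, going by these compounds, is how an amine or a fluorine in place of this hydroxy would read, and whether the number depends on the hydroxy at all or only on what is attached to its oxygen. On these data alone, it is equally open whether a longer chain on the same oxygen, such as ethyl or benzyl, would cost more or less than methyl, and whether the other hydroxy tolerates the same change.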